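A few compounds are considered here, and "the series" means these few. Any claim that something is new, unique, unknown or untested is made for them only; others in the source may bear on it.

Compound 1 `CNC(=O)c1cc(Oc2ccc(C(=O)/C=C/c3ccc(Cl)c(Cl)c3)cc2)ccn1` gives 11400 nM
Compound 2 `CNC(=O)c1cc(Oc2ccc(C(=O)/C=C/c3ccc(OC)cc3)cc2)ccn1` gives "not determined" (no result reported)

The measure used here is a functional assay on HepG2 cells (Homo sapiens) for cytotoxicity, read by MTT assay, with a stated time of 72 h; a lower number here means a stronger inhibitor, a higher number a weaker inhibitor. On this measure compound 2 has no place on the numbers: its entry reads "not determined" (no result reported) and no single figure exists for it. Compound 3 `CNC(=O)c1cc(Oc2ccc(C(=O)/C=C/c3cccc(Cl)c3Cl)cc2)ccn1` shares its core with compound 2 and has not yet been measured. Going by the values given here, the one structural change is 2,3-dichlorophenyl in place of 4-methoxyphenyl on a double-bonded chain carbon bound to a double-bonded chain carbon and it puts 2,3-dichlorophenyl in place of 4-methoxyphenyl on a double-bonded chain carbon bound to a double-bonded chain carbon.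

Among the compounds with values here, with no figure for compound 2, no step from it can be sized in this assay. Within the data shown here, the only guide is compound 1, which also carries a dichlorophenyl group and gives 11400 nM in that test. One compound is thin support, so the expectation is modest: a result close to that of compound 1, with no shift beyond the usual scatter in either direction. For compound 3 the estimated half-maximal inhibitory concentration is 12000 nM with an expected range from 5000 nM to 30000 nM once it is measured.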

Compound 3, half-maximal inhibitory concentration: > 50000 nM
Compound 3: no number, only a limit; the forecaster's own chance of this, stated with the estimate: 10%; middle value at least 4.1-fold (0.61 log units) from the limit.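

In this assay compound 3 stands only as a limit, not as a number: the limit of > 50000 nM in this assay, at which 1 of the 3 values shown sits.

As far as these compounds go, exchanging 3,4-dichlorophenyl for 2,3-dichlorophenyl on a double-bonded chain carbon bound to a double-bonded chain carbon gives an at least 4.3-fold higher number from compound 1 to compound 3 (0.64 log units; beyond the scatter), and since one end of this step is a limit, its full size remains unknown. Compound 1 alone could not show what this pair does. In this series, carrying a dichlorophenyl group does not by itself settle the result. Where the two chlorine atoms sit on the ring goes with a clear difference in the read-out, at least for these two compounds.

From the compounds shown here alone, compound 2 has no result, so steps involving it cannot be read, and how 4-methoxyphenyl compares with either dichlorophenyl group stays open. The compounds shown also leave open what a phenyl ring with a single chlorine, or one carrying an amine or a carboxylic acid, would give at this place, and they offer no reason for the difference between compound 1 and compound 3.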